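The source may report more compounds than this note shows. Statements on the series, on what has been measured and on what is new or still open speak of the compounds shown alone.

Of the compounds shown here, three sharing the same carbonyl-linked chain have been tested in an assay on HEK-293T cells for inhibition of diacylglycerol lipase-alpha (Homo sapiens), read by colorimetric assay; on this read-out higher numbers stand for weaker inhibition and lower numbers for stronger inhibition. Compound 1 `Cn1nnc(C(=O)CCCCCCc2ccccc2)n1` carries a 2-methyl-2H-tetrazol-5-yl group on the carbonyl carbon, and in this assay compound 1 reaches only the limit > 10000 nM, which is a boundary of the measurement and not a number. Compound 2 `COc1coc(C(=O)CCCCCCc2ccccc2)n1` carries a 4-methoxy-1,3-oxazol-2-yl group in that place, and compound 2 likewise gives only the limit > 10000 nM. Compound 3 `O=C(CCCCCCc1ccccc1)c1ncno1` carries a 1,2,4-oxadiazol-5-yl group there, and compound 3 also stops at the limit > 10000 nM. All three therefore sit at the same place, the limit described in the limit of > 10000 nM in this assay, at which 3 of the 3 values shown sit, so the steps a step that the two limits leave unreadable from compound 1 to compound 2, a step that the two limits leave unreadable from compound 1 to compound 3 and a step that the two limits leave unreadable from compound 2 to compound 3 cannot be read in size.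

Compound 4 `COc1cnc(C(=O)CCCCCCc2ccccc2)o1` has not been measured. It differs from compound 3 by a group of 7 heavy atoms (4 carbon, 1 nitrogen, 2 oxygen; one five-membered aromatic ring with 2 hetero atoms) in place of a group of 5 heavy atoms (2 carbon, 2 nitrogen, 1 oxygen; one five-membered aromatic ring with 3 hetero atoms), on a carbonyl carbon. For the measured compounds named here, none of the measured steps has a readable size, so none points in a direction. The closest comparison is compound 2, bearing the 4-methoxy-1,3-oxazol-2-yl group, which shows nothing but the limit. The step from compound 3 to compound 4 is therefore expected to be small or absent, a step that the limit leaves unreadable from compound 3 to compound 4. Compound 4 is estimated at 20000 nM, within a range from 5000 nM to 100000 nM, and most likely will again be reported only as a limit.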

Compound 4, half-maximal inhibitory concentration: > 10000 nM
Compound 4 gave a limit, no number; the forecaster's own chance of this, stated with the estimate: 85%; the middle value lies beyond the limit too.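

Compound 4, like compound 1, compound 2 and compound 3, gives no number in this assay, so no step among these compounds can be read in size. All four stop at the same boundary: the limit of > 10000 nM in this assay, at which 4 of the 4 values shown sit. The compounds shown leave open how strongly any of the four actually inhibits, and whether any group on the carbonyl carbon would give a readable number.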